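This account rests on a few compounds, and the source may have more. Where it says the series, first, only, none or still open, it means among the compounds named here.

Compound 1 `Fc1ccc(-c2csc(N/N=C/c3ccc(Cl)cc3Cl)n2)cc1` and compound 2 `Cc1ccc(-c2csc(N/N=C/c3ccc(Cl)cc3Cl)n2)cc1` share one core, while compound 3 `Fc1ccc(-c2csc(N/N=C/c3cccs3)n2)cc1` and the not yet measured compound 4 `Cc1ccc(-c2csc(N/N=C/c3cccs3)n2)cc1` share another; the difference between the two cores is not broken down here. In a functional assay, read by spectrophotometry, with a stated time of 15 min, tested at 80 ug/mL (on this read-out lower numbers stand for a weaker effect and higher numbers for a stronger effect at the one concentration tested), compound 1 gives 95.5%, and compound 2 gives 90.7%. The change that separates them, (methyl in place of fluoro on an aromatic carbon), moves the read-out by a number 4.8 percentage points lower from compound 1 to compound 2 (within the scatter). In this assay compound 3 gives 66.3%, a number that stands beyond the scatter from both compound 1 and compound 2. Compound 4 carries the same change relative to compound 3, (methyl in place of fluoro on an aromatic carbon), at a place described in exactly the same words as before. Because the earlier step of a number 4.8 percentage points lower from compound 1 to compound 2 (within the scatter) lay within the scatter, a step of comparable size is expected here, a number 4.3 percentage points lower from compound 3 to compound 4 (within the scatter). In this assay compound 4 is therefore estimated to give 62%, with the expected range running from 50% to 74%. This expectation rests on a single measured pair, compound 1 and compound 2, and so is held loosely.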

Compound 4, a percentage reported as inhibition, at one concentration (the size of the read-out at that concentration, not a potency): 97.8%
Estimate against measurement, compound 4: 35.8 percentage points below, outside the stated range (above it).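

In this assay, methyl in place of fluoro on an aromatic carbon gives a number 31.5 percentage points higher from compound 3 to compound 4 (beyond the scatter), and this step does not match the one seen earlier for the same change on the other core: the same change on two cores in this assay, a number 4.8 percentage points lower (within the scatter) from compound 1 to compound 2 and a number 31.5 percentage points higher (beyond the scatter) from compound 3 to compound 4, 36.3 percentage points apart, beyond the scatter of two such steps

In this series, then, the size of the step measured on one core did not carry over to the other, so the effect of this change has to be read core by core. This rests on just two pairs, however, and it does not show which feature of the cores separates the steps, nor does it give a rule for any further core.

The compounds shown leave open how a methoxy group, an amine or a carboxylic acid in the same place would behave on either core. They also leave open which part of the difference between the two cores goes with the divergence, and whether it would persist at other concentrations.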